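The source may report more compounds than this note shows. Statements on the series, on what has been measured and on what is new or still open speak of the compounds shown alone.

Measured compounds:
- compound 1, `CCn1c([C@@H](C)NS(=O)(=O)c2ccc(Cl)cc2)nc2ccc(C(F)(F)F)cc21`: > 100 mL.min-1.g-1
- compound 2, `CCn1c([C@@H](C)NS(=O)(=O)c2ccc(Cl)cc2)nc2cc(C#N)ccc21`: 71 mL.min-1.g-1
- compound 3, `CCn1c([C@@H](C)NS(=O)(=O)c2ccc(NC(C)=O)c(C)c2)nc2ccc(C(F)(F)F)cc21`: > 100 mL.min-1.g-1

In an ADME assay (liver) for metabolic stability, with Liver microsome (Homo sapiens) as the target, read by LC-MS, using microsomes and NADPH, with a stated time of 5 min, at 37 degrees C (on this read-out lower numbers stand for slow clearance and higher numbers for fast clearance), compound 1 gives > 100 mL.min-1.g-1, which is a limit of the assay and not a number. Compound 3 likewise gives > 100 mL.min-1.g-1 in this assay, also a limit. Only compound 2, at 71 mL.min-1.g-1, returns a number, and that number sits not far under (the limit of > 100 mL.min-1.g-1 in this assay, at which 2 of the 3 values shown sit). For the measured compounds named here, compound 1 therefore stands at the fast end of what this assay can report, with no measured step to say how far any single change moves the read-out.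

The unmeasured compound 4, `CCn1c([C@@H](C)NS(=O)(=O)c2cnc(NC(C)=O)s2)nc2ccc(C(F)(F)F)cc21`, differs from compound 1 in one place: 2-acetamido-1,3-thiazol-5-yl in place of 4-chlorophenyl on a sulfonyl sulfur. Going by the values given here, no step between two measured compounds covers a change of this kind, so the size of the expected step rests on the structures alone. A move towards slower clearance is expected, an at least 1.6-fold lower number from compound 1 to compound 4 (0.22 log units; that floor lies within the scatter), but with the upper end of the range still reaching the limit, since compound 3 carrying an acetamido group also gives > 100 mL.min-1.g-1. For compound 4 the estimate is 60 mL.min-1.g-1, within 25 mL.min-1.g-1 to 100 mL.min-1.g-1.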

Compound 4, intrinsic clearance in microsomes: 15 mL.min-1.g-1
Beside the measured number, compound 4's estimate is 4.0-fold (0.60 log units) above it; measured number outside the range, below it.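

In this assay, for the compounds shown here, 2-acetamido-1,3-thiazol-5-yl in place of 4-chlorophenyl on a sulfonyl sulfur gives an at least 6.6-fold lower number from compound 1 to compound 4 (0.82 log units; beyond the scatter), the only measured step so far, and it shows that a change at this position can bring the read-out well clear of the top of the reportable range. As far as these compounds go, the printed size is a floor and the full size stays unknown, because compound 1 sits at a limit of the assay: the limit of > 100 mL.min-1.g-1 in this assay, at which 2 of the 4 values shown sit. Compound 3, which also carries an acetamido group, gives > 100 mL.min-1.g-1, a limit of the assay and not a number, so an acetamido group on the sulfonyl side does not by itself go with a value off the limit.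

From the compounds shown here alone, whether the step belongs to the five-membered aromatic ring, to the acetamido group on it, or to the two together remains open, and a plain amine in place of the acetamido group would help to separate them. Also open, going by these compounds, is whether a nitrile on the core, as in compound 2, would lower the number further when combined with 2-acetamido-1,3-thiazol-5-yl.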